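Swapping fluoro for chloro on the phenyl of compound 3

This account rests on a few compounds, and the source may have more. Where it says the series, first, only, none or still open, it means among the compounds named here.

Compound 3 `O=C(Nc1ccc(Oc2ccnc3[nH]ccc23)c(F)c1)c1cc2cccnc2n(-c2ccc(F)cc2)c1=O` gives the lowest number of the three measured, 36 nM in a functional assay on HT-29 cells (Homo sapiens) for antiproliferative activity, read by MTT assay, with a stated time of 72 h; a higher number here means a weaker inhibitor, a lower number a stronger inhibitor; compound 2 `O=C(Nc1ccc(Oc2ccnc3[nH]ccc23)c(F)c1)c1cc2cccnc2n(-c2ccccc2)c1=O` gives 160 nM and compound 1 `O=C(Nc1ccc(Oc2ccnc3[nH]ccc23)cc1)c1cc2cccnc2n(-c2ccc(Cl)cc2)c1=O` gives 280 nM. Compound 4 `O=C(Nc1ccc(Oc2ccnc3[nH]ccc23)c(F)c1)c1cc2cccnc2n(-c2ccc(Cl)cc2)c1=O` carries chloro in place of fluoro on an aromatic carbon, that is, 4-fluorophenyl becomes 4-chlorophenyl. Among the measured compounds shown here, the only single-point step measured concerns this ring: a 4.4-fold lower number from compound 2 to compound 3 (0.65 log units; beyond the scatter). For the measured compounds named here, no measured pair isolates chloro against fluoro; compound 1 and compound 3 differ in two places at once, so their values cannot be read as that swap alone. The step to compound 4 in this assay is therefore expected to be small, a 1.7-fold higher number from compound 3 to compound 4 (0.22 log units; within the scatter), in either direction. Compound 4 is estimated at 60 nM, with a range from 20 nM to 200 nM.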

Compound 4, half-maximal inhibitory concentration: 82 nM
The estimate for compound 4 lay 1.4-fold (0.14 log units) below the measured number, within the range that was stated.
By their numbers in this assay, from the lowest: compound 3; then compounds 4, 2 and 1 (each within the scatter of the next, the first and the last beyond it).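

In this assay, the identity of the halogen on this phenyl ring can be told apart: chloro in place of fluoro gives a 2.3-fold higher number from compound 3 to compound 4 (0.36 log units; beyond the scatter). Chloro in place of hydrogen at the same place gives a 2.0-fold lower number from compound 2 to compound 4 (0.29 log units; within the scatter), a step within the scatter, so it shows no clear gain over the unsubstituted phenyl. Fluoro in place of hydrogen on an aromatic carbon, now seen a second time as a 3.4-fold lower number from compound 1 to compound 4 (0.53 log units; beyond the scatter), gives a similar step on two cores: the same change on two cores in this assay, a 4.4-fold lower number (0.65 log units; beyond the scatter) from compound 2 to compound 3 and a 3.4-fold lower number (0.53 log units; beyond the scatter) from compound 1 to compound 4, 1.3-fold (0.11 log units) apart, within the scatter of two such steps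

The compounds shown leave open how a methyl, a methoxy or an amine at this place would compare with fluoro. With only these groups, no trend across substituents can be drawn.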